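Series notes: bromo to cyano on the sulfonyl phenyl

This account rests on a few compounds, and the source may have more. Where it says the series, first, only, none or still open, it means among the compounds named here.

Compound 1 `O=C1/C(=C/c2cccnc2)CN(S(=O)(=O)c2ccc(Br)cc2)C/C1=C\c1ccccc1F` gives 12800 nM in a functional assay on QGY-7703 cells (Homo sapiens) for cytotoxicity, read by MTT assay, with a stated time of 24 h; a higher number here means a weaker inhibitor, a lower number a stronger inhibitor. Compound 2 `N#Cc1ccc(S(=O)(=O)N2C/C(=C\c3cccnc3)C(=O)/C(=C/c3ccccc3F)C2)cc1` gives 15800 nM in this assay. The change cyano in place of bromo on an aromatic carbon produced a 1.2-fold higher number from compound 1 to compound 2 (0.09 log units; within the scatter). Compound 3 `O=C1/C(=C/c2ccncc2)CN(S(=O)(=O)c2ccc(Br)cc2)C/C1=C\c1ccccc1C(F)(F)F` gives 7060 nM in this assay; the difference between the core of compound 3 and the core of compound 1 is not broken down here, and its value stands near that of compound 1. For the measured compounds named here, compound 4 `N#Cc1ccc(S(=O)(=O)N2C/C(=C\c3ccncc3)C(=O)/C(=C/c3ccccc3C(F)(F)F)C2)cc1` is not yet measured; it differs from compound 3 by cyano in place of bromo on an aromatic carbon, the same change, at the same place, as the one between compound 1 and compound 2. For compound 4 the expected step is a 1.2-fold higher number from compound 3 to compound 4 (0.08 log units; within the scatter), a small one, because a 1.2-fold higher number from compound 1 to compound 2 (0.09 log units; within the scatter) already lay within the scatter. Compound 4 is therefore estimated at 8500 nM, with a range from 4000 nM to 18000 nM.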

Compound 4, half-maximal inhibitory concentration: 6290 nM
Estimate against measurement, compound 4: 1.4-fold (0.13 log units) above, and the stated range covers the measured number.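

Cyano in place of bromo gave a 1.1-fold lower number from compound 3 to compound 4 (0.05 log units; within the scatter), so the swap again leaves the number within the scatter, and the two cores do not differ in this assay: the same change on two cores in this assay, a 1.2-fold higher number (0.09 log units; within the scatter) from compound 1 to compound 2 and a 1.1-fold lower number (0.05 log units; within the scatter) from compound 3 to compound 4, 1.4-fold (0.14 log units) apart, within the scatter of two such steps. Across these two pairs, bromo and cyano can therefore be exchanged on either core without a readable shift. This shows agreement between two steps that are both too small to read, not that a defined effect carries over, and it cannot exclude a small real effect on either core or predict the outcome on any further core.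

Open, from the compounds shown here alone, is whether other groups at this place, such as an amine, a carboxylic acid or a methoxy group, would move the number beyond the scatter. Also open, going by these compounds, is how the parts that separate the core of compound 1 from the core of compound 3 act individually.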